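A furan-2-yl replaces the 2-fluorobenzyl on the ring nitrogen

A few compounds are considered here, and "the series" means these few. Any claim that something is new, unique, unknown or untested is made for them only; others in the source may bear on it.

Compound 1 `CCOC(=O)c1ccc(-c2nn(Cc3ccccc3F)c3ccccc23)cc1` was tested in a functional assay on cells (Platelet, Homo sapiens) for inhibition; a lower number here means a stronger inhibitor, a higher number a weaker inhibitor. In this assay compound 1 reaches only a limit, > 10000 nM. Two close relatives accompany it. Compound 2 `CCOC(=O)c1ccc(-c2nn(Cc3cccc(F)c3)c3ccccc23)cc1` also gives only a limit in this assay, > 10000 nM. Compound 3 `CCOC(=O)c1ccc(-c2nn(Cc3ccc(F)cc3)c3ccccc23)cc1` likewise stops at a limit in this assay, > 10000 nM. The steps among them, a step that the two limits leave unreadable from compound 1 to compound 2, a step that the two limits leave unreadable from compound 1 to compound 3 and a step that the two limits leave unreadable from compound 2 to compound 3, cannot be sized because of the limit of > 10000 nM in this assay, at which 3 of the 3 values shown sit. Compound 4 `CCOC(=O)c1ccc(-c2nn(-c3ccco3)c3ccccc23)cc1` has not yet been measured; it differs from compound 1 by furan-2-yl in place of 2-fluorobenzyl on an aromatic nitrogen. Among the measured compounds shown here, no measured step bears on this change, and none of the three can be sized. Compound 4 is therefore expected to sit at about 15000 nM, between 3000 nM and 60000 nM. The expected step that the limit leaves unreadable from compound 1 to compound 4 is accordingly not readable beyond the scatter.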

Compound 4, half-maximal inhibitory concentration: > 10000 nM
Compound 4: no number, only a limit; the forecaster's own chance of this, stated with the estimate: 80%; the middle value lies beyond the limit too.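

No step from compound 1, compound 2 or compound 3 to compound 4 can be read, because all four stop at a limit: the limit of > 10000 nM in this assay, at which 4 of the 4 values shown sit.

The compounds shown leave open how far apart these four lie in this assay and whether any group on the ring nitrogen gives a measurable value.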